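Triazole Aryl Swaps at the Antiproliferation Limit

The source may hold more compounds than are shown below. What is called first, only, known or untested is meant among the compounds shown, and "the series" means these compounds.

Compound 1, `CCc1ccccc1-n1nncc1CN1C(=O)C2(C(C#N)=C(N)Oc3c(N)cc4nc5ccccc5nc4c32)c2ccccc21`, gives > 50000 nM in an ADME assay on HUVEC cells (Homo sapiens) for antiproliferative activity, read by MTT assay, with a stated time of 48 h (on this read-out lower numbers stand for stronger inhibition and higher numbers for weaker inhibition), which is a limit of the assay rather than a number.
Compound 2, `N#CC1=C(N)Oc2c(N)cc3nc4ccccc4nc3c2C12C(=O)N(Cc1cnnn1-c1cccc(C(F)(F)F)c1)c1ccccc12`, gives > 50000 nM in this assay, again only a limit.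
Compound 3, `N#CC1=C(N)Oc2c(N)cc3nc4ccccc4nc3c2C12C(=O)N(Cc1cnnn1-c1ccc([N+](=O)[O-])cc1)c1ccccc12`, gives > 50000 nM in this assay, again only a limit.

Compound 3 thus stands exactly where the other two measured compounds stand: at the limit, with no number that would place it higher or lower than either of them; (the limit of > 50000 nM in this assay, at which 3 of the 3 values shown sit). The three steps among the measured compounds, a step that the two limits leave unreadable from compound 1 to compound 2, a step that the two limits leave unreadable from compound 1 to compound 3 and a step that the two limits leave unreadable from compound 2 to compound 3, each join two limits and cannot be read for size or direction.

The new compound 4, `Cc1ccc(Cl)cc1-n1nncc1CN1C(=O)C2(C(C#N)=C(N)Oc3c(N)cc4nc5ccccc5nc4c32)c2ccccc21`, keeps the shared core and alters only the aryl group on the aromatic nitrogen: 5-chloro-2-methylphenyl in place of 4-nitrophenyl on an aromatic nitrogen. All three measured steps bear on this kind of change, an exchange of one aryl group on that nitrogen for another, and none of them moved any compound out of the limit. No step beyond the scatter is therefore expected in this assay, in either direction. The step that the limit leaves unreadable from compound 3 to compound 4 is expected to be flat. Compound 4 is estimated at 60000 nM, between 20000 nM and 200000 nM, and is expected most likely to be reported only as a limit once more.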

Compound 4, half-maximal inhibitory concentration: > 50000 nM
Compound 4: no number, only a limit (the forecaster's own chance of this, stated with the estimate: 85%); the middle value lies beyond the limit too.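

In this assay compound 4 gives > 50000 nM as a limit of the assay and not a number. Its steps from compound 1, compound 2 and compound 3 therefore cannot be read for size or direction: the limit of > 50000 nM in this assay, at which 4 of the 4 values shown sit.

The compounds shown leave open how far beyond the limit each one lies, and whether any aryl group on that aromatic nitrogen would give a readable number.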